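A few compounds are considered here, and "the series" means these few. Any claim that something is new, unique, unknown or untested is made for them only; others in the source may bear on it.

Compound 2 `Cc1nsc2ncn([C@H]3C[C@H](O)[C@@H](CO)O3)c12` was tested in a functional assay on KB cells (Homo sapiens) for antiproliferative activity; a lower number here means a stronger inhibitor, a higher number a weaker inhibitor. In this assay compound 2 gives > 100000 nM, which is a limit of the assay rather than a number. Compound 1 `CSc1nc2cnsc2n1[C@H]1C[C@H](O)[C@@H](CO)O1` shares that outcome: in this assay compound 1 gives > 100000 nM, again a limit. Both measured values therefore sit at the limit of > 100000 nM in this assay, at which 2 of the 2 values shown sit. Compound 3 `CSc1nc2snc(C)c2n1[C@H]1C[C@H](O)[C@@H](CO)O1` has not yet been tested. It differs from compound 2 by methylsulfanyl in place of hydrogen on an aromatic carbon. Among the measured compounds shown here, with no measured step to build on, the expected step that the limit leaves unreadable from compound 2 to compound 3 is none beyond the scatter. Compound 3 is accordingly estimated to give 150000 nM, within 50000 nM to 500000 nM.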

Compound 3, half-maximal inhibitory concentration: 30000 nM
The estimate for compound 3 lay 5.0-fold (0.70 log units) above the measured number; the whole stated range lies above it.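

On this aromatic carbon, between two ring nitrogen atoms, methylsulfanyl in place of hydrogen gives a change that can be read in this assay: an at least 3.3-fold lower number from compound 2 to compound 3 (0.52 log units; beyond the scatter). This shows that the position is not silent, since a group placed here moves the read-out off the limit and gives a real number. As far as these compounds go, the true size of the step stays unknown, since one end of it is only a limit: the limit of > 100000 nM in this assay, at which 2 of the 3 values shown sit.

From the compounds shown here alone, whether the sulfur or its methyl carries the change remains open. So does whether an amine or a longer chain at this carbon would lower the number further.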